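Terminal group variation on the piperidine-side chain, step to compound 4

The compounds below may be only part of what the source reports. "The series", "measured", "known", "first", "only" and "open" are said of these compounds alone.

Measured compounds and values in an in vitro assay on AV12 cells for binding affinity to Neuropeptide Y receptor type 1 (Homo sapiens); a lower number here means a stronger inhibitor, a higher number a weaker inhibitor:
compound 1, `C=CCCN1CCC(CCCn2c(COc3ccccc3)nc3c(OCCCN4CCCCC4)cccc32)CC1`: 0.707 nM
compound 2, `c1ccc(OCc2nc3c(OCCCN4CCCCC4)cccc3n2CCCC2CCN(CCC3CCCCC3)CC2)cc1`: 0.285 nM
compound 3, `C(=C\c1ccccc1)\CN1CCC(CCCn2c(COc3ccccc3)nc3c(OCCCN4CCCCC4)cccc32)CC1`: 0.183 nM

Compound 2 stands second highest of the three numbers. Its nearest neighbour is compound 3, reached by a 1.6-fold lower number from compound 2 to compound 3 (0.19 log units; within the scatter), so the two are not separable; the furthest is compound 1, from which compound 2 is reached by a 2.5-fold lower number from compound 1 to compound 2 (0.39 log units; beyond the scatter).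

Compound 4, `O=C(CCCN1CCC(CCCn2c(COc3ccccc3)nc3c(OCCCN4CCCCC4)cccc32)CC1)c1ccccc1`, is not yet measured in this assay. It differs from compound 2 by benzoylmethyl in place of cyclohexyl on a saturated chain carbon, two bonds along the chain from an amine nitrogen in a ring.

Among the measured compounds shown here, two measured steps bear on it. Replacing vinyl by cyclohexyl at the same place gave a 2.5-fold lower number from compound 1 to compound 2 (0.39 log units; beyond the scatter), and exchanging cyclohexylmethyl for 2-phenylethenyl gave a 1.6-fold lower number from compound 2 to compound 3 (0.19 log units; within the scatter). Moving from a saturated ring to an aromatic terminus therefore left the number essentially unchanged, and the added carbonyl has no precedent here. A step near the scatter in either direction is expected, with a slight lean toward a higher number because the nearest analogous change was a 1.6-fold lower number from compound 2 to compound 3 (0.19 log units; within the scatter).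

Compound 4 is expected to give about 0.4 nM, estimated between 0.13 nM and 1.2 nM, meaning a 1.4-fold higher number from compound 2 to compound 4 (0.15 log units; within the scatter).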

Compound 4, inhibition constant: 0.132 nM
The estimate for compound 4 lay 3.0-fold (0.48 log units) above the measured number, within the range that was stated.
By their numbers in this assay, from the lowest: compounds 4, 3 and 2 (each within the scatter of the next, the first and the last beyond it); then compound 1.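

In this assay, a terminus carrying a carbonyl is accepted at this place: benzoylmethyl in place of cyclohexyl gives a 2.2-fold lower number from compound 2 to compound 4 (0.33 log units; beyond the scatter) and separates compound 4 from a saturated-ring terminus, which compound 3 did not do. Against the 2-phenylethenyl group, 2-benzoylethyl gives a 1.4-fold lower number from compound 3 to compound 4 (0.14 log units; within the scatter) and so leaves these two aromatic termini unresolved, even though they differ in the carbonyl and the unsaturated link. Measured from the vinyl end of the series, the change gives a 5.4-fold lower number from compound 1 to compound 4 (0.73 log units; beyond the scatter), the widest step among the four compounds, and the first to show this range at this place.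

Still open, as far as these compounds go, is whether the carbonyl or the longer chain carries the step, which a 3-phenylpropyl terminus, a hydroxyl in place of the carbonyl, or a terminal amine would help separate. No supporting data bear on the cause of these steps.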